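The source may hold more compounds than are shown below. What is called first, only, known or untested is meant among the compounds shown, and "the series" means these compounds.

Measured so far:
- compound 1, `CCCCCCCCCCCCCCCC(=O)O[C@H]1[C@H](O)[C@H](n2ccc(N)nc2=O)O[C@@H]1CO`: 0.24 ug/mL
- compound 2, `CCCC(=O)OC[C@H]1O[C@@H](n2ccc(N)nc2=O)[C@@H](O)[C@@H]1OC(=O)CCC`: 0.11 ug/mL
- compound 3, `CCCCCCCCCCCCCCCC(=O)OC[C@H]1O[C@@H](n2ccc(N)nc2=O)[C@@H](O)[C@@H]1OC(=O)CCCCCCCCCCCCCCC`: > 10 ug/mL

In a functional assay on HeLa cells (Homo sapiens) for cytotoxicity, read by cell counting, with a stated time of 48 h (a higher number here means that more compound is needed for the effect, a lower number that less compound is needed), compound 1 gives 0.24 ug/mL, the higher of the two numbers obtained. Compound 2 gives 0.11 ug/mL, a lower number, and the gap between compound 1 and compound 2 lies beyond the scatter of repeated measurements. For compound 3 the result in this assay is a limit only, > 10 ug/mL, and not a number; it is the limit of > 10 ug/mL in this assay, at which 1 of the 3 values shown sits, and is kept apart from the comparison of the numbers.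

Compound 4, `CCCCCCCCC(=O)O[C@H]1[C@H](O)[C@H](n2ccc(N)nc2=O)O[C@@H]1CO`, has not been measured. Against compound 1 the change is hydrogen in place of heptyl on a saturated chain carbon, eight bonds along the chain from a carbonyl carbon. For the measured compounds named here, no step between two measured compounds matches this change, so there is no direct precedent for its size. The only bearing the shown numbers give is that the compound with shorter ester chains, compound 2, sits at 0.11 ug/mL, below compound 1. For compound 3, the compound with the longest chains, the result is a limit only.

For compound 4 in this assay the expected value is 0.15 ug/mL, with a range from 0.05 ug/mL to 0.5 ug/mL. The step this expectation implies, a 1.6-fold lower number from compound 1 to compound 4 (0.20 log units; within the scatter), is a modest move downward, not clearly beyond the scatter.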

Compound 4, concentration for half-maximal effect: 0.05 ug/mL
For compound 4 the middle estimate is 3.0-fold (0.48 log units) above the measured one; low and high end bracket the measured number.
By their numbers in this assay, from the lowest: compound 4; then compound 2; then compound 1. At a limit, above all of these: compound 3.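

In this assay, hydrogen in place of heptyl on a saturated chain carbon, eight bonds along the chain from a carbonyl carbon, gives a 4.8-fold lower number from compound 1 to compound 4 (0.68 log units; beyond the scatter). The earlier compounds shown here offered no step in a single place, whereas this pair shows that the number responds to the length of this chain alone, and that the shorter chain needs less compound for the effect. Nothing measured in the series accounts for the size of this step.

From the compounds shown here alone, two chain lengths at this position fix no trend, so it remains open whether a still shorter chain, a longer chain than in compound 1, or a chain carrying an amine or a carboxylic acid would move the number further in this assay. Compound 3 gives > 10 ug/mL, a limit only, so the series holds no number for that compound.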